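Phenoxy to fluoro on the aryl of the imide series

A few compounds are considered here, and "the series" means these few. Any claim that something is new, unique, unknown or untested is made for them only; others in the source may bear on it.

Of the compounds shown here, two have numbers so far. Compound 1 `CC[C@@H](c1nc2ccc(C(=O)O)cc2n1C)N1C(=O)CN(c2ccc(Oc3ccccc3)cc2)C1=O` gives 210000 nM in an assay on isolated protein for inhibition of Bile acid receptor (Homo sapiens), read by TR-FRET and LanthaScreen; on this read-out lower numbers stand for stronger inhibition and higher numbers for weaker inhibition. Going by the values given here, compound 2 `CC(C)C[C@@H](c1nc2ccc(C(=O)O)cc2n1C)N1C(=O)CN(c2ccc(Oc3ccccc3)cc2)C1=O` gives 43400 nM in this assay and so holds the lowest of the two numbers; the only step recorded is a 4.8-fold lower number from compound 1 to compound 2 (0.68 log units; beyond the scatter), isopropyl in place of methyl on a saturated chain carbon, two bonds along the chain from an amide-type nitrogen in a ring and an aromatic carbon.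

Compound 3 `CC(C)C[C@@H](c1nc2ccc(C(=O)O)cc2n1C)N1C(=O)CN(c2ccc(F)cc2)C1=O` keeps the isobutyl side chain of compound 2 and changes the aryl end: fluoro in place of phenoxy on an aromatic carbon, on an aromatic carbon of a six-membered aromatic ring of carbon only, para to a large group. Among the compounds with values here, no measured step touches this position, so the side-chain step gives no guide here. With the large phenoxy gone, a higher number in this assay is expected for compound 3, around a 2.8-fold higher number from compound 2 to compound 3 (0.44 log units; beyond the scatter), with wide uncertainty. Compound 3 is estimated at 120000 nM, between 35000 nM and 400000 nM.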

Compound 3, half-maximal inhibitory concentration: 399000 nM
Estimate against measurement, compound 3: 3.3-fold (0.52 log units) below; the measured number falls inside the stated range.
By their numbers in this assay, from the lowest: compound 2; then compounds 1 and 3 (each within the scatter of the next).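

In this assay, fluoro in place of phenoxy on this aromatic carbon gives a 9.2-fold higher number from compound 2 to compound 3 (0.96 log units; beyond the scatter) and so shows that the number responds to the aryl end of the series, not only to the side chain. The earlier step, a 4.8-fold lower number from compound 1 to compound 2 (0.68 log units; beyond the scatter) and also beyond the scatter, concerned the side chain alone. No measurement on hand accounts for the size of the new step.

The compounds shown do not separate the loss of the whole phenoxy group from the loss of its ring alone, so methoxy, benzyloxy or phenyl on this carbon would be the informative groups to compare. On these data alone, whether the phenoxy-to-fluoro step carries over to the ethyl side chain of compound 1 also remains open.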